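Pyridin-2-yl exchanged for a seven-atom ring group

A few compounds are considered here, and "the series" means these few. Any claim that something is new, unique, unknown or untested is made for them only; others in the source may bear on it.

Compound 1 `Cc1cccc(C(=O)NCN2CCC(c3ccccn3)CC2)c1` stands lowest of the three measured numbers in a functional assay on HEK293 cells for agonist activity at D(4) dopamine receptor (Homo sapiens), read by FLIPR (a higher number here means that more compound is needed for the effect, a lower number that less compound is needed), where compound 1 gives 9 nM. Compound 2 `Cc1cc(C)cc(NC(=O)CN2CCC(c3cccc[n+]3[O-])CC2)c1` gives 52 nM, and compound 3 `CSc1cccc(NC(=O)CN2CCC(c3cccc[n+]3[O-])CC2)c1` gives 100 nM; the step of a 1.9-fold higher number from compound 2 to compound 3 (0.28 log units; within the scatter) lies within the scatter. Compound 4 `Cc1cccc(C(=O)NCN2CCC(c3cccc[n+]3[O-])CC2)c1` differs from compound 1 as follows: a group of 7 heavy atoms (5 carbon, 1 nitrogen, 1 oxygen; one six-membered aromatic ring with 1 hetero atom) in place of a group of 6 heavy atoms (5 carbon, 1 nitrogen; one six-membered aromatic ring with 1 hetero atom), on a saturated ring carbon. Within the data shown here, no measured pair shows this exact change on an otherwise identical core, so the step between compound 2 and compound 3 does not bear on it directly. Still, compound 2 and compound 3 both carry the entering group and their numbers sit well above that of compound 1, so a modest rise is expected, namely a 3.3-fold higher number from compound 1 to compound 4 (0.52 log units; beyond the scatter). Compound 4 is thus estimated at 30 nM, within 10 nM to 90 nM.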

Compound 4, half-maximal effective concentration: 89 nM
For compound 4 the middle estimate is 3.0-fold (0.47 log units) below the measured one; the range from low to high includes it.
By their numbers in this assay, from the lowest: compound 1; then compounds 2, 4 and 3 (each within the scatter of the next).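

In this assay, exchanging pyridin-2-yl for the seven-atom ring group, which holds one oxygen more, gives a 9.9-fold higher number from compound 1 to compound 4 (1.00 log units; beyond the scatter) on an otherwise identical core. This single change on a saturated ring carbon is therefore enough to move the number beyond the scatter, which compound 2 and compound 3 could not show, as both differ from compound 1 in more than one place. From the compounds shown here alone, whether other groups here, such as pyridin-3-yl or plain phenyl, would keep the low number of compound 1 remains open. Nothing available explains the size of this step.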